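Shifting a Chlorine Atom: What to Expect for Compound 3

A few compounds are considered here, and "the series" means these few. Any claim that something is new, unique, unknown or untested is made for them only; others in the source may bear on it.

Two compounds have been measured in a functional assay on RAW264.7 cells (Mus musculus) for inhibition, read by Griess assay, with stated times of 2 h and 24 h; on this read-out higher numbers stand for weaker inhibition and lower numbers for stronger inhibition:

- Compound 1, `COc1ccc([C@@H]2CC(=O)c3c(O)cc(OCc4cn(Cc5ccc(C(F)(F)F)cc5)nn4)cc3O2)cc1O`: 17700 nM
- Compound 2, `COc1ccc([C@@H]2CC(=O)c3c(O)cc(OCc4cn(Cc5ccccc5Cl)nn4)cc3O2)cc1O`: 6140 nM

Among the compounds with values here, compound 2 holds the lowest of the two numbers; its nearest neighbour is compound 1, and the only measured step between them is a 2.9-fold lower number from compound 1 to compound 2 (0.46 log units; beyond the scatter). Compound 3, `COc1ccc([C@@H]2CC(=O)c3c(O)cc(OCc4cn(Cc5ccc(Cl)cc5)nn4)cc3O2)cc1O`, has not yet been measured in this assay. It differs from compound 2 by 4-chlorophenyl in place of 2-chlorophenyl on a saturated chain carbon bound to an aromatic nitrogen. Within the data shown here, the single measured step bears on this change only loosely: it swapped both the group on the ring and where that group sits, and it was modest in size. Compound 3 keeps the chlorine of compound 2 but moves it, and the name of its group, 4-chlorophenyl, echoes the 4-(trifluoromethyl)phenyl of compound 1, which gave the higher number. The data therefore pull in two directions. For compound 3 the expected step is a 1.5-fold higher number from compound 2 to compound 3 (0.17 log units; within the scatter), small and quite possibly within the scatter. The estimate for compound 3 in this assay is 9000 nM, with a range from 3000 nM to 30000 nM.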

Compound 3, half-maximal inhibitory concentration: 17800 nM
Beside the measured number, compound 3's estimate is 2.0-fold (0.30 log units) below it, and the stated range covers the measured number.
By their numbers in this assay, from the lowest: compound 2; then compounds 1 and 3 (each within the scatter of the next).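

Compound 2 and compound 3 hold the same atoms, so moving the chlorine alone accounts for the change in this assay, a 2.9-fold higher number from compound 2 to compound 3 (0.46 log units; beyond the scatter): the swap from 2-chlorophenyl to 4-chlorophenyl on this saturated chain carbon is a clean test of place, whereas the earlier step changed both the group and where it sat. Keeping the group's place and exchanging only trifluoromethyl for chloro on an aromatic carbon gives a 1.0-fold higher number from compound 1 to compound 3 (0.00 log units; within the scatter), so compound 1 and compound 3 cannot be told apart, and among these three compounds only compound 2, with its 2-chlorophenyl, stands apart from the others. Nothing available explains why the place of the chlorine matters here.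

Three compounds cannot show whether the lower number of compound 2 belongs to chlorine itself or would also appear with a bromine or a methoxy group in place of that chlorine. A plain phenyl with no chlorine at all, which would show whether the 2-chlorophenyl lowers the number or the 4-substituted groups raise it, also lies outside the compounds shown.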